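The source may report more compounds than this note shows. Statements on the series, on what has been measured and on what is new or still open speak of the compounds shown alone.

Compound 2, `COc1ccc(C2C(C#N)=C(/N=C/c3ccc(Cl)cc3)Oc3nc(Nc4ccc(S(N)(=O)=O)cc4)sc32)cc1`, gives the lower of the two numbers measured in a functional assay on MCF7 cells (Homo sapiens) for cytotoxicity, read by sulforhodamine B assay, with a stated time of 48 h; on this read-out lower numbers stand for stronger inhibition and higher numbers for weaker inhibition: compound 2 gives 9550 nM, while compound 1, `COc1ccc(C2C(C#N)=C(N)Oc3nc(Nc4ccc(S(N)(=O)=O)cc4)sc32)cc1`, gives 27500 nM. Among the compounds with values here, the single measured step, a 2.9-fold lower number from compound 1 to compound 2 (0.46 log units; beyond the scatter), concerns a different change and gives no direct guide here. Compound 3, `COc1ccc(C2C(C#N)=C(/N=C/c3cccc(Br)c3)Oc3nc(Nc4ccc(S(N)(=O)=O)cc4)sc32)cc1`, differs from compound 2 by 3-bromophenyl in place of 4-chlorophenyl on a carbon with a double bond to nitrogen. Within the data shown here, no measured step changes this ring in such a way, so the step in this assay is expected to stay within the usual scatter. Compound 3 is therefore estimated at 9500 nM, with a range from 4000 nM to 23000 nM, meaning an expected 1.0-fold lower number from compound 2 to compound 3 (0.00 log units; within the scatter).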

Compound 3, half-maximal inhibitory concentration: 9390 nM
Beside the measured number, compound 3's estimate is 1.0-fold (0.01 log units) above it; low and high end bracket the measured number.
By their numbers in this assay, from the lowest: compounds 3 and 2 (each within the scatter of the next); then compound 1.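

In this assay, replacing 4-chlorophenyl with 3-bromophenyl on the carbon with a double bond to nitrogen gives a 1.0-fold lower number from compound 2 to compound 3 (0.01 log units; within the scatter), so this ring tolerates a change of halogen and its ring position together without a shift beyond the scatter. The drop first seen with the added chlorinated ring also appears with the brominated one, as a 2.9-fold lower number from compound 1 to compound 3 (0.47 log units; beyond the scatter). No measured evidence explains this result. Still open, as far as these compounds go, is how far the number would move with a carboxylic acid or an amine on this ring, or a longer chain in its place.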